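Pyrimidinyl for Naphthyl on the Shared Core: Cytotoxicity

This account rests on a few compounds, and the source may have more. Where it says the series, first, only, none or still open, it means among the compounds named here.

Compound 1 `COc1ccc(-c2cnc(Nc3ccc(C#N)cc3)nc2Oc2c(C)cc(C#N)cc2C)cc1`: in an ADME assay on MT4 cells (Homo sapiens) for cytotoxicity, read by MTT assay, with a stated time of 5 days (on this read-out higher numbers stand for lower toxicity in this test and lower numbers for higher toxicity in this test), compound 1 reaches only a limit of the assay, > 279000 nM.
Compound 2 `Cc1cc(C#N)cc(C)c1Oc1nc(Nc2ccc(C#N)cc2)ncc1-c1cccc2ccccc12`: in this assay compound 2 likewise reaches only a limit of the assay, > 267000 nM.

Compound 2 therefore stands at a limit rather than at a number. Within the data shown here, the one measured step, a step that the two limits leave unreadable from compound 1 to compound 2, cannot be read because both of its ends sit at limits, namely the limit of > 267000 nM in this assay, at which 1 of the 2 values shown sits, and (the limit of > 279000 nM in this assay, at which 1 of the 2 values shown sits). Compound 3 `Cc1cc(C#N)cc(C)c1Oc1nc(Nc2ccc(C#N)cc2)ncc1-c1cncnc1` differs from compound 2 by pyrimidin-5-yl in place of naphthalen-1-yl on an aromatic carbon. No measured step bears on this change, and the only step shown is unreadable, so in this assay no step beyond the scatter is expected; a further limit is the likelier outcome. The step from compound 2 to compound 3 is expected to be an at least 1.0-fold lower number from compound 2 to compound 3 (0.01 log units; that floor lies within the scatter). Compound 3 is thus estimated at 260000 nM, within 90000 nM to 300000 nM.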

Compound 3, half-maximal cytotoxic concentration: > 298000 nM
Compound 3 was reported as a limit; the forecaster's own chance of this, stated with the estimate: 80%; middle value at least 1.1-fold (0.05 log units) from the limit.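

In this assay compound 3 gives > 298000 nM, a limit of the assay. Among these compounds, with compound 1, compound 2 and compound 3 all at limits, no step among them can be read. The compounds shown leave open whether 4-methoxyphenyl, naphthalen-1-yl and pyrimidin-5-yl differ in cytotoxicity on the shared core.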